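This account rests on a few compounds, and the source may have more. Where it says the series, first, only, none or still open, it means among the compounds named here.

In a functional assay on SK-OV-3 cells (Homo sapiens) for antiproliferative activity, read by MTT assay, with a stated time of 72 h (a higher number here means a weaker inhibitor, a lower number a stronger inhibitor), compound 1 `O=C(CCc1cccc2c1B(O)OC2)NCc1ccccc1`, which carries benzyl on the amide-type nitrogen, reaches only a limit, > 100000 nM. Compound 2 `Cc1ccc(NC(=O)CCc2cccc3c2B(O)OC3)cc1`, with 4-methylphenyl there, gives 860 nM, and compound 3 `O=C(CCc1cccc2c1B(O)OC2)Nc1cccc(I)c1`, with 3-iodophenyl, gives 630 nM. The step between these two, a 1.4-fold lower number from compound 2 to compound 3 (0.14 log units; within the scatter), lies within the scatter, which leaves them level at the low end of the numbers shown.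

Compound 4 `O=C(CCc1cccc2c1B(O)OC2)Nc1cccc(-c2cccc(Cl)c2)c1` has 3-chlorophenyl in place of iodo on an aromatic carbon, meta to a large group: 3-chlorophenyl in place of iodo on an aromatic carbon. Two measured steps are large, an at least 110-fold lower number from compound 1 to compound 2 (2.06 log units; beyond the scatter) and an at least 150-fold lower number from compound 1 to compound 3 (2.20 log units; beyond the scatter), but both replace benzyl on the amide-type nitrogen and leave this aromatic carbon out of the comparison. The nearest evidence is a 1.4-fold lower number from compound 2 to compound 3 (0.14 log units; within the scatter), a change of the substituted phenyl group that stays within the scatter. Going by the values given here, no measured compound carries a second aromatic ring at this place, so the direction is poorly defined. In this assay, the expected result is therefore no clear step beyond the scatter, with a slight lean toward a lower number, and the estimated step is a 1.8-fold lower number from compound 3 to compound 4 (0.26 log units; within the scatter). For compound 4 the estimated value is 350 nM, with an expected range from 60 nM to 2000 nM.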

Compound 4, half-maximal inhibitory concentration: 300 nM
Estimate against measurement, compound 4: 1.2-fold (0.07 log units) above, and the stated range covers the measured number.
By their numbers in this assay, from the lowest: compound 4; then compounds 3 and 2 (each within the scatter of the next). At a limit, above all of these: compound 1.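

In this assay, the aromatic carbon meta to a large group takes a far bigger substituent than iodo: 3-chlorophenyl brings 7 heavy atoms and a six-membered aromatic ring of carbon only in place of a single iodine atom, and the result is a 2.1-fold lower number from compound 3 to compound 4 (0.32 log units; beyond the scatter). The earlier compounds differed only in the group on the amide-type nitrogen, and among those with a directly attached phenyl group the only listed step, a 1.4-fold lower number from compound 2 to compound 3 (0.14 log units; within the scatter), gave no separation, so this is the first step within that aryl amide set to pass beyond the scatter. Nothing given here bears on why the number falls with this change.

The compounds shown leave open whether the step belongs to the added ring or to its chlorine, a question that a plain phenyl at this place, or an amine or a carboxylic acid on the second ring, would help to settle. Also open, on these data alone, is how the number would respond to a longer chain between the shared core and the amide carbonyl while 3-chlorophenyl stays in place.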